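A few compounds are considered here, and "the series" means these few. Any claim that something is new, unique, unknown or untested is made for them only; others in the source may bear on it.

Of the compounds shown here, three sharing one core have been tested in a functional assay on SK-OV-3 cells (Homo sapiens) for inhibition, read by sulforhodamine B assay, with a stated time of 48 h; on this read-out higher numbers stand for lower toxicity in this test and lower numbers for higher toxicity in this test. Compound 1 `O=C(Nc1cccc(-n2cc(-c3ccncc3)c(-c3ccc(Cl)c(O)c3)n2)c1)Nc1ccc(Cl)c(Cl)c1` gives > 32500 nM, which is a limit of the assay and not a measured number. Compound 2 `COc1cc(-c2nn(-c3cccc(NC(=O)c4ccc(Cl)c(C(F)(F)F)c4)c3)cc2-c2ccncc2)ccc1Cl` gives > 32500 nM, again only a limit. Compound 3 `O=C(Nc1cccc(-n2cc(-c3ccncc3)c(-c3ccc(Cl)c(O)c3)n2)c1)Nc1cc(C(F)(F)F)cc(C(F)(F)F)c1` gives > 50000 nM, also a limit. Compound 2 therefore stands where the others stand: no measurable toxicity, a picture summed up by the limit of > 32500 nM in this assay, at which 2 of the 3 values shown sit, and (the limit of > 50000 nM in this assay, at which 1 of the 3 values shown sits).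

Compound 4 `COc1cc(-c2nn(-c3cccc(NC(=O)Nc4cccc(C(F)(F)F)c4)c3)cc2-c2ccncc2)ccc1Cl` has not yet been measured. It differs from compound 2 in one place: (3-(trifluoromethyl)phenyl)amino in place of 4-chloro-3-(trifluoromethyl)phenyl on a carbonyl carbon. Compound 1 and compound 3 already carry an amino group on their carbonyl carbon, and both give only limits in this assay, so the change is not expected to bring a measurable number. The expected step from compound 2 to compound 4 is a step that the limit leaves unreadable from compound 2 to compound 4, meaning none beyond the scatter. Compound 4 is expected to give about 40000 nM, somewhere between 20000 nM and 80000 nM, and most likely to be reported once more only as a limit.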

Compound 4, concentration lethal to 50% of the cells: > 50000 nM
Compound 4: a limit, no number (the forecaster's own chance of this, stated with the estimate: 85%); at least 1.2-fold (0.09 log units) between middle value and limit.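

Compound 2 and compound 4 each give only a limit in this assay, so no step can be read between them. The compounds shown leave open which of the two groups on the carbonyl carbon brings higher toxicity, and at what concentration, if any, toxicity appears.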